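This account rests on a few compounds, and the source may have more. Where it says the series, first, only, none or still open, it means among the compounds named here.

Among the measured compounds shown here, in a functional assay on HT-29 cells (Homo sapiens) for inhibition, read by MTT assay, with a stated time of 48 h (on this read-out higher numbers stand for weaker inhibition and lower numbers for stronger inhibition), compound 2 (`COc1cc(-c2nnc(SCC(=O)c3ccccc3)n2-c2ccc(N(C)C)cc2)cc(OC)c1OC`) gives 45200 nM as the only number so far. Compound 1 (`CCSc1nnc(-c2cc(OC)c(OC)c(OC)c2)n1-c1ccc(N(C)C)cc1`) gives > 60000 nM and this is a limit of the assay. Compound 3 (`CCOC(=O)CSc1nnc(-c2cc(OC)c(OC)c(OC)c2)n1-c1ccc(N(C)C)cc1`) differs from compound 2 by one change (ethoxy in place of phenyl on a carbonyl carbon): ethoxy in place of phenyl on a carbonyl carbon. For the measured compounds named here, the sole measured step (an at least 1.3-fold lower number from compound 1 to compound 2 (0.12 log units; that floor lies within the scatter)) concerns the same benzoyl, and its floor lies within the scatter, so no step beyond the scatter is expected in this assay here. The expected step (a 1.1-fold higher number from compound 2 to compound 3 (0.04 log units; within the scatter)) is therefore small. For compound 3 the estimate is 50000 nM with an expected range of 22000 nM to 100000 nM in this assay.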

Compound 3, half-maximal inhibitory concentration: 28800 nM
Compound 3: middle estimate off by 1.7-fold (0.24 log units), on the high side; low and high end bracket the measured number.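

On a carbonyl carbon, ethoxy in place of phenyl leaves the number within the scatter in this assay, with a 1.6-fold lower number from compound 2 to compound 3 (0.20 log units; within the scatter). Ethoxycarbonyl is the first change in the series to clear the scatter, with an at least 2.0-fold lower number from compound 1 to compound 3 (0.31 log units; beyond the scatter). That step is only a floor: compound 1 gives > 60000 nM, which is a limit of the assay.

As far as these compounds go, whether a carboxylic acid or an amide at this carbonyl carbon would shift the number further stays open. From the compounds shown here alone, the full size of the step from the methyl compound also stays open.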